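Adding trifluoromethyl to compound 3

The source may report more compounds than this note shows. Statements on the series, on what has been measured and on what is new or still open speak of the compounds shown alone.

Compound 1 `CC1=NN(C(=O)CCl)C(c2cc(Cl)ccc2O)C1`: 20300 nM
Compound 2 `CC1=NN(C(=O)CCl)C(c2cc(Br)ccc2O)C1`: 12300 nM
Compound 3 `CC1=NN(S(=O)(=O)c2ccccc2)C(c2cc(Br)ccc2O)C1`: > 60000 nM, a limit

All three compounds were tested in a functional assay on HepG2 cells (Homo sapiens) for antiproliferative activity, read by MTT assay, with a stated time of 48 h; a higher number here means that more compound is needed for the effect, a lower number that less compound is needed. Compound 3 stands at the limit of > 60000 nM in this assay, at which 1 of the 3 values shown sits, and this is a limit of the assay, not a number. Compound 1 and compound 2, by contrast, both returned numbers.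

Compound 4 `CC1=NN(S(=O)(=O)c2ccc(C(F)(F)F)cc2)C(c2cc(Br)ccc2O)C1` differs from compound 3 by one exchange: trifluoromethyl in place of hydrogen on an aromatic carbon. This places trifluoromethyl in place of hydrogen on an aromatic carbon, para to a large group.

Among the compounds with values here, only one measured step is available, and it bears on this change only loosely. That step, a 1.7-fold lower number from compound 1 to compound 2 (0.22 log units; within the scatter), is bromo in place of chloro on an aromatic carbon, a different exchange from the one at issue. Within the data shown here, no measured step covers trifluoromethyl in place of hydrogen.

No step beyond the scatter is therefore expected in this assay, in either direction, and compound 4 may also be reported only as a limit. The expected step, counted from a limit rather than a number, is an at least 1.2-fold lower number from compound 3 to compound 4 (0.07 log units; that floor lies within the scatter). For compound 4 the estimate is 50000 nM, with an expected range of 18000 nM to 110000 nM.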

Compound 4, half-maximal effective concentration: 22100 nM
The estimate for compound 4 lay 2.3-fold (0.35 log units) above the measured number, within the range that was stated.
By their numbers in this assay, from the lowest: compounds 2, 1 and 4 (each within the scatter of the next). At a limit, above all of these: compound 3.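

In this assay, trifluoromethyl in place of hydrogen on an aromatic carbon, para to a large group, gives an at least 2.7-fold lower number from compound 3 to compound 4 (0.43 log units; beyond the scatter). Within the data shown here, that step is only a floor, since the value it starts from is a limit and not a number: the limit of > 60000 nM in this assay, at which 1 of the 4 values shown sits. Unlike the earlier compounds, whose one measured step concerned a halogen exchange, this pair shows that the number in this assay responds to a change at this place on the six-membered aromatic ring of carbon only, and that this sulfonyl compound can give a measured number once trifluoromethyl is present.

The compounds shown leave open whether the step belongs to trifluoromethyl in particular, or whether a methoxy group, a nitrile, a fluorine atom or a carboxylic acid at the same place would move the number in the same direction and to the same extent. They also leave open what the trifluoromethyl group does here, and whether the same exchange would give a comparable step with chloro in place of bromo on the other aromatic ring.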